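The source may hold more compounds than are shown below. What is called first, only, known or untested is meant among the compounds shown, and "the series" means these compounds.

Measured so far:
compound 1 `Cc1cccc(CNc2nc(-c3ccccc3C(C)C)ncc2C)c1` — 130 nM
compound 2 `Cc1cccc(C(CO)Nc2nc(-c3ccccc3C(C)C)ncc2C)c1` — 21000 nM

In an assay on a protein complex for inhibition of ubiquitin carboxyl-terminal hydrolase 1/WD repeat-containing protein 48 (Homo sapiens), read by fluorescence (a lower number here means a stronger inhibitor, a higher number a weaker inhibitor), compound 1 gives the lower of the two numbers; its nearest neighbour is compound 2, reached by a 160-fold higher number from compound 1 to compound 2 (2.21 log units; beyond the scatter), a large step. Compound 3 `Cc1cnc(-c2ccccc2C(C)C)nc1NCC1CCN(C)CC1` differs from compound 1 at a different place: 1-methylpiperidin-4-yl in place of 3-methylphenyl on a saturated chain carbon bound to a nitrogen on an aromatic ring. Going by the values given here, no measured step exchanges the ring on the chain carbon, so the step from compound 1 to compound 2 does not directly inform this change. With a non-aromatic ring replacing the aromatic one, a weaker inhibitor is expected, with an estimated step of a 15-fold higher number from compound 1 to compound 3 (1.19 log units; beyond the scatter). Compound 3 is thus estimated at 2000 nM, within a range from 300 nM to 15000 nM.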

Compound 3, half-maximal inhibitory concentration: "not active" (no number reported)
No number was reported for compound 3; the estimate stays without a comparison.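

Going by these compounds alone, compound 3 was reported as "not active", with no number, so no step from compound 1 to compound 3 can be read. Going by these compounds, how far 1-methylpiperidin-4-yl in place of 3-methylphenyl shifts the number stays open, and no evidence here bears on this result.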